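The compounds below may be only part of what the source reports. "The series", "measured", "known", "first", "only" and "open" are said of these compounds alone.

Of the compounds shown here, three of one shared core have been tested in a functional assay on A549 cells (Homo sapiens) for cytotoxicity, read by MTT assay, with a stated time of 48 h; on this read-out higher numbers stand for weaker inhibition and lower numbers for stronger inhibition. Compound 1 `Cc1ccc(S(=O)(=O)/N=C(/CCNC2=CC(=O)c3ccccc3C2=O)Nc2cccc(C)c2)cc1` gives 18700 nM in this assay. Compound 2 `Cc1ccc(S(=O)(=O)/N=C(/CCNC2=CC(=O)c3ccccc3C2=O)Nc2ccc(Cl)cc2Cl)cc1` gives 32900 nM, and compound 3 `COc1cc(N/C(CCNC2=CC(=O)c3ccccc3C2=O)=N\S(=O)(=O)c2ccc(C)cc2)cc(OC)c1OC` gives 7940 nM, the lowest of the three numbers. The step of a 1.8-fold higher number from compound 1 to compound 2 (0.25 log units; within the scatter) was within the scatter, whereas the steps of a 2.4-fold lower number from compound 1 to compound 3 (0.37 log units; beyond the scatter) and a 4.1-fold lower number from compound 2 to compound 3 (0.62 log units; beyond the scatter) were modest but beyond it, so compound 3 stands apart from the other two.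

Compound 4 `Cc1ccc(S(=O)(=O)/N=C(\N)CCNC2=CC(=O)c3ccccc3C2=O)cc1` has not yet been measured in this assay. It differs from compound 3 by hydrogen in place of 3,4,5-trimethoxyphenyl on an amine nitrogen. Within the data shown here, all three measured steps exchanged one aryl group for another on that nitrogen; none removed the aryl group altogether, so no measured step bears directly on this change. Since the aryl swaps shifted the numbers only modestly, and the best of them gave compound 3 its low number, removing the group is expected to move the number back up. For compound 4 the estimate is 30000 nM, with a range from 10000 nM to 100000 nM, meaning an expected step of a 3.8-fold higher number from compound 3 to compound 4 (0.58 log units; beyond the scatter).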

Compound 4, half-maximal inhibitory concentration: 26600 nM
Beside the measured number, compound 4's estimate is 1.1-fold (0.05 log units) above it; the measured number falls inside the stated range.
By their numbers in this assay, from the lowest: compound 3; then compounds 1, 4 and 2 (each within the scatter of the next).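

Taking the 3,4,5-trimethoxyphenyl group off the amine nitrogen and leaving only hydrogen gives a 3.4-fold higher number from compound 3 to compound 4 (0.53 log units; beyond the scatter) in this assay, so this aryl group goes with the lower number among these compounds. The other two aryl groups show no such separation from hydrogen: replacing 2,4-dichlorophenyl gives a 1.2-fold lower number from compound 2 to compound 4 (0.09 log units; within the scatter) and replacing 3-methylphenyl gives a 1.4-fold higher number from compound 1 to compound 4 (0.15 log units; within the scatter), so an aryl group on this nitrogen does not by itself lower the number, and compounds 1 and 2 go against any such rule. Nothing available explains why 3,4,5-trimethoxyphenyl stands apart.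

From the compounds shown here alone, it remains open whether a phenyl ring with a single methoxy group, or with hydroxyl groups in place of the methoxy groups, would stay near compound 3 or fall back towards compound 4. Going by these compounds, a benzyl group on this nitrogen is equally open.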